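The source may report more compounds than this note shows. Statements on the series, on what has been measured and on what is new or still open speak of the compounds shown alone.

Compound 1 `c1ccc(CNCc2cn(Cc3ccccc3)c3ccccc23)cc1` is the weakest of the three measured compounds in an assay on isolated protein for inhibition of Amine oxidase [flavin-containing] B (Rattus norvegicus) (a lower number here means a stronger inhibitor, a higher number a weaker inhibitor), where compound 1 gives 362000 nM. Its nearest neighbour is compound 2 `C#CCN(Cc1ccccc1)Cc1cc2ccccc2n1C`, which in this assay gives 60000 nM, while compound 3 `C#CCN(C)Cc1cc2ccccc2n1C` gives 3 nM, far beyond both.

Compound 4 `CC(C)NCc1cn(Cc2ccccc2)c2ccccc12` differs from compound 1 by isopropyl in place of benzyl on an amine nitrogen. Among the compounds with values here, the only measured step that touches a similar place is a 20000-fold lower number from compound 2 to compound 3 (4.30 log units; beyond the scatter), where a hydrogen replaced a phenyl on a saturated chain carbon bound to an amine nitrogen. That step, however, was set within a compound carrying a propargyl group on the same nitrogen, which compound 1 and compound 4 lack; compound 1 also carries its benzyl on a different part of the shared core and a second benzyl on the ring nitrogen. The loss of the phenyl ring from the amine substituent points toward a lower number, but the very large size of the step from compound 2 to compound 3 cannot be assumed here. A modest step in the same direction is expected, namely a 6.0-fold lower number from compound 1 to compound 4 (0.78 log units; beyond the scatter). Compound 4 is therefore estimated at 60000 nM in this assay, with a range from 10000 nM to 300000 nM.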

Compound 4, inhibition constant: 438000 nM
Compound 4: the middle estimate sits 7.3-fold (0.86 log units) below what was measured, outside the stated range (above it).
By their numbers in this assay, from the lowest: compound 3; then compound 2; then compounds 1 and 4 (each within the scatter of the next).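

In this assay the change from benzyl to isopropylamino's isopropyl on an amine nitrogen gives a 1.2-fold higher number from compound 1 to compound 4 (0.08 log units; within the scatter) and so leaves the two compounds indistinguishable, even though a six-membered aromatic ring of carbon leaves with the benzyl. Within the data shown here, the only earlier step at a comparable place, a 20000-fold lower number from compound 2 to compound 3 (4.30 log units; beyond the scatter) in the same assay, suggested that losing a phenyl on a saturated chain carbon bound to an amine nitrogen could matter enormously, but that step was read in compounds carrying a propargyl group on the nitrogen, and this pair shows that such a loss need not repeat its size on the core of compound 1. Nothing available explains why the step is so flat here.

From the compounds shown here alone, whether this position is equally indifferent to other groups stays open, since a cyclopropyl, a longer alkyl chain or a carboxylic acid on this amine nitrogen would each test it further. Going by these compounds, it also remains open whether a propargyl group on this nitrogen of the core of compound 1 would bring a large step of the kind seen with the earlier pair.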